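The source may report more compounds than this note shows. Statements on the series, on what has been measured and on what is new or still open speak of the compounds shown alone.

Measured compounds:
compound 1 `Cn1cc(SCc2nnc(SCc3ccccc3C#N)n2-c2c(Cl)cccc2Cl)c2ccccc21` — 78600 nM
compound 2 `Cn1cc(SCc2nnc(SCc3ccc(Cl)cc3F)n2-c2c(Cl)cccc2Cl)c2ccccc21` — 87300 nM

In a toxicity assay on HEK-293T cells (Homo sapiens) for cytotoxicity, read by CCK-8 assay, with a stated time of 48 h (on this read-out lower numbers stand for higher toxicity in this test and higher numbers for lower toxicity in this test), compound 2 gives the higher of the two numbers, with compound 1 close by, a difference within the scatter. Compound 3 `Cn1cc(SCc2nnc(SCc3ccc(OC(F)(F)F)c(Cl)c3)n2-c2c(Cl)cccc2Cl)c2ccccc21` differs from compound 2 by 3-chloro-4-(trifluoromethoxy)phenyl in place of 4-chloro-2-fluorophenyl on a saturated chain carbon bound to a sulfur. Among the compounds with values here, the only step that bears on this is a 1.1-fold higher number from compound 1 to compound 2 (0.05 log units; within the scatter), an exchange of the same aryl group on the same chain carbon that left the number unchanged. Compound 3 is therefore expected to show no step beyond the scatter, a 1.2-fold lower number from compound 2 to compound 3 (0.07 log units; within the scatter), and compound 3 is estimated at 75000 nM, with a range from 30000 nM to 160000 nM.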

Compound 3, half-maximal cytotoxic concentration: 77700 nM
Compound 3: middle estimate off by 1.0-fold (0.02 log units), on the low side, and the stated range covers the measured number.
By their numbers in this assay, from the lowest: compounds 3, 1 and 2 (each within the scatter of the next).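

In this assay, the position on a saturated chain carbon bound to a sulfur also accepts 3-chloro-4-(trifluoromethoxy)phenyl, a group with more heavy atoms and a hydrogen-bond acceptor, with a 1.1-fold lower number from compound 2 to compound 3 (0.05 log units; within the scatter) and a 1.0-fold lower number from compound 1 to compound 3 (0.01 log units; within the scatter). All three aryl groups shown at this position therefore lie within the scatter of one another in this test. Nothing available explains this result.

On these data alone, all three groups are substituted phenyl rings, so the effect of an amine, a carboxylic acid or a longer alkyl chain here remains open. As far as these compounds go, how changes elsewhere on the shared core would read in this test also remains open.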